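The source may hold more compounds than are shown below. What is called first, only, known or untested is meant among the compounds shown, and "the series" means these compounds.

The two measured compounds, with their half-maximal effective concentrations in a functional assay on 1321-N1 cells for agonist activity at Free fatty acid receptor 1 (Homo sapiens), read by calcium flux, with a stated time of 0.4 s; on this read-out higher numbers stand for an effect only at larger amounts of compound and lower numbers for an effect already at smaller amounts:

Compound 1 `O=C(O)CCc1ccc(C#CC2CCCC2)cc1`: 490 nM
Compound 2 `C=C(C)C#Cc1ccc(CCC(=O)O)c(F)c1`: 81.3 nM

Compound 1 stands highest of the two numbers. Its nearest neighbour, compound 2, gives the lower number, and the gap between the two lies beyond the usual scatter; the two structures differ in more than one place, so nothing more is drawn from that pair than what the two values show.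

The step under consideration leads from compound 1 to compound 3 `O=C(O)CCc1ccc(C#CC2CCCCC2)cc1`, which has not yet been measured in this assay. The change is cyclohexyl in place of cyclopentyl on a triple-bonded carbon, that is, the five-membered ring is exchanged for a six-membered ring of carbon only, while the rest of the core of compound 1 stays as it is. Within the data shown here, no measured pair shows this exchange, so no step of known size can be set beside it.

On that basis the step is expected to be a 1.4-fold lower number from compound 1 to compound 3 (0.15 log units; within the scatter), small, and at most a little beyond the usual scatter, with a slight lean toward a lower number. Compound 3 is expected to give 350 nM, in a range from 120 nM to 1000 nM.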

Compound 3, half-maximal effective concentration: 513 nM
The estimate for compound 3 lay 1.5-fold (0.17 log units) below the measured number; measured number inside the range.
By their numbers in this assay, from the lowest: compound 2; then compounds 1 and 3 (each within the scatter of the next).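

In this assay, among these compounds, the exchange of cyclopentyl for cyclohexyl on a triple-bonded carbon gives the first step that can be read at this position, a 1.0-fold higher number from compound 1 to compound 3 (0.02 log units; within the scatter), and it stays within the scatter. With the rest of the core of compound 1 unchanged, the six-membered ring of carbon only and the five-membered ring of carbon only therefore cannot be told apart by this read-out, something the earlier pair could not show because its two structures differ in more than one place. The data at hand offer nothing that accounts for this equivalence.

The compounds shown leave open whether this tolerance extends beyond these two rings of carbon only, for instance to a smaller cyclopropyl ring, a flat phenyl ring, a piperidine ring carrying an amine nitrogen, or an open tert-butyl group at the same place. Among the compounds shown here, they also leave open how much of the lower number of compound 2 belongs to its branched alkenyl group and how much to its fluorine, since no single-place step separates the two.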